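Working notes: from compound 2 to compound 3

The compounds below may be only part of what the source reports. "The series", "measured", "known", "first", "only" and "open" are said of these compounds alone.

Measured in a functional assay on HeLa cells (Homo sapiens) for antiproliferative activity, with a stated time of 24 h; on this read-out higher numbers stand for weaker inhibition and lower numbers for stronger inhibition:
- Compound 1 `NC(=O)c1c(NC(=O)c2ccccc2)sc2c1CCN(C(=S)Nc1ccccc1Cl)C2` gives > 50000 nM as a limit
- Compound 2 `NC(=O)c1c(NC(=O)c2ccccc2I)sc2c1CCN(C(=S)Nc1ccccc1Cl)C2` gives > 50000 nM as a limit

Compound 2 has only a limit in this assay and no number. The record so far is the limit of > 50000 nM in this assay, at which 2 of the 2 values shown sit.

The change to compound 3 `NC(=O)c1c(NC(=O)c2ccc(C(F)(F)F)cc2)sc2c1CCN(C(=S)Nc1ccccc1Cl)C2` is this: 4-(trifluoromethyl)phenyl in place of 2-iodophenyl on a carbonyl carbon.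

For the measured compounds named here, the only measured step, which alters the same group on the carbonyl carbon, is a step that the two limits leave unreadable from compound 1 to compound 2, so it gives no size to carry over. No step beyond the scatter is therefore expected in this assay, and a limit is again the likeliest result. The expected step is an at least 1.1-fold lower number from compound 2 to compound 3 (0.04 log units; that floor lies within the scatter). The estimate for compound 3 is 45000 nM, with an expected range from 15000 nM to 50000 nM.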

Compound 3, half-maximal inhibitory concentration: 44000 nM
Compound 3: the middle estimate sits 1.0-fold (0.01 log units) above what was measured; low and high end bracket the measured number.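

In this assay, for the compounds shown here, compound 3 is the first to carry a number rather than a limit. The change on the carbonyl carbon, 4-(trifluoromethyl)phenyl in place of 2-iodophenyl, gives an at least 1.1-fold lower number from compound 2 to compound 3 (0.05 log units; that floor lies within the scatter), and the trifluoromethyl group alone gives an at least 1.1-fold lower number from compound 1 to compound 3 (0.05 log units; that floor lies within the scatter). Both are only floors, so neither change shows a gain beyond the scatter, and the record still rests mainly on the limit: the limit of > 50000 nM in this assay, at which 2 of the 3 values shown sit.

Open, from the compounds shown here alone, is whether a different group on this carbonyl carbon, such as a phenyl ring bearing an amine or a carboxylic acid, or a longer chain, would move the number clearly. Going by these compounds, the step between compound 1 and compound 2 cannot be read, and the full size of the two steps to compound 3 also stays open.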